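This account rests on a few compounds, and the source may have more. Where it says the series, first, only, none or still open, it means among the compounds named here.

The two measured compounds share one core and differ only in the group on the aromatic ring. Going by the values given here, compound 2 `O=C1CSC(c2ccccc2Cl)N1CCN1CCCCC1` gives 100% in an ADME assay on Vero cells (Chlorocebus sabaeus) for cytotoxicity, read by neutral red uptake, tested at 12.3 ug/mL (a lower number here means a stronger effect, a higher number a weaker effect of the compound at the concentration tested), the higher of the two numbers known. Compound 1 `O=C1CSC(c2ccc(Cl)cc2)N1CCN1CCCCC1` gives 90% in this assay, and the step of a number 10 percentage points higher from compound 1 to compound 2 (within the scatter). Compound 3 `COc1ccccc1C1SCC(=O)N1CCN1CCCCC1` differs from compound 2 by methoxy in place of chloro on an aromatic carbon. Among the compounds with values here, no measured step swaps one kind of group for another, so the only guide is that the single step seen stayed within the scatter. Compound 3 is therefore expected to give 95%, with a range from 80% to 100%. The step of a number 5 percentage points lower from compound 2 to compound 3 (within the scatter) is expected to be none beyond the scatter.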

Compound 3, a percentage reported as activity, at one concentration (the size of the read-out at that concentration, not a potency): 100%
Compound 3: the middle estimate sits 5 percentage points below what was measured; low and high end bracket the measured number.
By their numbers in this assay, from the lowest: compounds 1, 2 and 3 (each within the scatter of the next).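

On an aromatic carbon ortho to a large group, methoxy in place of chloro gives no change at the digits printed from compound 2 to compound 3 (within the scatter) in this assay. Compound 1 and compound 2 differ only in where chloro sits, whereas this step changes the group itself, from one heavy atom to two and with one hydrogen-bond acceptor added. No measurement shown explains this result. The compounds shown leave open whether an amine, a carboxylic acid or a longer chain such as butoxy at this place would also stay within the scatter.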